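The compounds below may be only part of what the source reports. "The series", "measured", "known", "first", "only" and "open" are said of these compounds alone.

Series on the shared core of compound 1 `COc1cccc(Cc2cc(-c3ccccc3)nn(CC(=O)Nc3ccc(F)cc3)c2=O)c1`, varied at the aryl attached to that core. In a functional assay on HL-60 cells (Homo sapiens), read by calcium flux (on this read-out higher numbers stand for an effect only at larger amounts of compound and lower numbers for an effect already at smaller amounts), compound 1 gives only a limit, > 50000 nM. Compound 2 `COc1cccc(Cc2cc(-c3ccc(C)cc3)nn(CC(=O)Nc3ccc(F)cc3)c2=O)c1` carries a methyl on the same aryl. In this assay compound 2 likewise gives only a limit, > 50000 nM. The step from a step that the two limits leave unreadable from compound 1 to compound 2 therefore has no readable size; compound 2 stands at the limit of > 50000 nM in this assay, at which 2 of the 2 values shown sit, together with compound 1. Compound 3 `COc1cccc(Cc2cc(-c3ccc(F)cc3)nn(CC(=O)Nc3ccc(F)cc3)c2=O)c1` is not yet measured; its change from compound 2 is fluoro in place of methyl on an aromatic carbon. Among the measured compounds shown here, the single measured step concerns the same aryl, yet it offers no size to carry over, and for this assay no step beyond the scatter is expected: the step from a number no higher from compound 2 to compound 3 (the limit leaves the size open) is expected to leave compound 3 at the limit as well. Compound 3 is estimated at 50000 nM in this assay, between 20000 nM and 150000 nM, most probably reported as a limit only.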

Compound 3, half-maximal effective concentration: > 50000 nM
Compound 3 was reported as a limit; the forecaster's own chance of this, stated with the estimate: 80%; the middle value lies on the limit itself.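

In this assay, among the compounds shown here, compound 1, compound 2 and compound 3 all give only a limit, so no step among them can be read: the limit of > 50000 nM in this assay, at which 3 of the 3 values shown sit.

The compounds shown leave open how far each lies from that limit, and whether any change at this aryl gives a readable value.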